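The source may report more compounds than this note shows. Statements on the series, on what has been measured and on what is new or still open speak of the compounds shown alone.

Measured compounds in an ADME assay on A549 cells (Homo sapiens) for cytotoxicity, read by MTT assay; a lower number here means that less compound is tolerated, a higher number that more compound is tolerated:

- compound 1, `C[Si](C)(C)C#Cc1c[nH]c(=O)[nH]c1=O`: 268000 nM
- compound 2, `CCC#Cc1c[nH]c(=O)[nH]c1=O`: 253000 nM
- compound 3, `O=c1[nH]cc(C#CC2CC2)c(=O)[nH]1`: 251000 nM

All three numbers lie within the scatter of one another. Compound 3 stands with compound 2 as its nearest neighbour, a 1.0-fold lower number from compound 2 to compound 3 (0.00 log units; within the scatter), and with compound 1 as its furthest, a 1.1-fold lower number from compound 1 to compound 3 (0.03 log units; within the scatter); neither gap is a real difference. The third step, a 1.1-fold lower number from compound 1 to compound 2 (0.03 log units; within the scatter), is likewise flat. Across the series, exchanging the group on the triple-bonded carbon has so far left the tolerated concentration unchanged.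

Compound 4, `CCCCC#Cc1c[nH]c(=O)[nH]c1=O`, continues this exchange: butyl in place of cyclopropyl on a triple-bonded carbon. For the measured compounds named here, the steps that bear on it are those that swap the same position, from compound 2 to compound 3 (cyclopropyl for ethyl) and from compound 1 to compound 2, both within the scatter. Nothing in the data distinguishes one group at this position from another, so no step beyond the scatter is expected in this assay, in either direction. Compound 4 is estimated at 250000 nM, with a range of 150000 nM to 420000 nM. The expected step is a 1.0-fold lower number from compound 3 to compound 4 (0.00 log units; within the scatter), within the scatter, pending the measurement.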

Compound 4, half-maximal cytotoxic concentration: 250000 nM
Estimate against measurement, compound 4: no gap at the digits printed; measured number inside the range.
By their numbers in this assay, from the lowest: compounds 4, 3, 2 and 1 (each within the scatter of the next).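

Notes on the group on the triple-bonded carbon, read in this assay: butyl in place of the cyclopropyl ring gives no real difference (a 1.0-fold lower number from compound 3 to compound 4 (0.00 log units; within the scatter)), and the same holds for the extension of ethyl to butyl (a 1.0-fold lower number from compound 2 to compound 4 (0.01 log units; within the scatter)) and for the all-carbon butyl against the silicon-bearing group of compound 1 (a 1.1-fold lower number from compound 1 to compound 4 (0.03 log units; within the scatter)). The flat picture therefore now covers an open chain of four carbons as well as ethyl, the three-membered ring and the silicon-bearing group, and none of the four compounds goes against it, so neither the ring, the silicon nor the chain length separates these compounds at this position. No measurement is available that would explain why these exchanges leave the tolerated concentration unchanged.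

Every group shown at this position consists of carbon and hydrogen, with silicon in compound 1 only, and none of them carries a hydrogen-bond donor or acceptor, so an amine, a hydroxyl, a carboxylic acid, a phenyl ring or a longer chain on the triple-bonded carbon remains open. From the compounds shown here alone, whether the same flat picture would hold in a cell line other than A549 also remains open, as does any change to the shared core.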